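The source may report more compounds than this note shows. Statements on the series, on what has been measured and on what is new or still open speak of the compounds shown alone.

Going by the values given here, in a functional assay on M21 cells (Homo sapiens) for antiproliferative activity, read by sulforhodamine B assay, with a stated time of 48 h (a higher number here means a weaker inhibitor, a lower number a stronger inhibitor), compound 1 `O=C1NCCN1c1ccc(S(=O)(=O)Nc2ccc(F)cc2)cc1` gives 230 nM, the only exact number so far. Compound 2 `CCCCCCCc1ccc(NS(=O)(=O)c2ccc(N3CCNC3=O)cc2)cc1` reads > 1000 nM, which is a limit of the assay and not a number. Among the compounds with values here, replacing fluoro with heptyl on an aromatic carbon accounts for the one measured step, an at least 4.3-fold higher number from compound 1 to compound 2 (0.63 log units; beyond the scatter).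

Compound 3 `O=C1NCCN1c1ccc(S(=O)(=O)Nc2ccc(F)c(F)c2)cc1` carries a smaller change to the core of compound 1: fluoro in place of hydrogen on an aromatic carbon. A 4-fluorophenyl thus becomes a 3,4-difluorophenyl, with the new fluoro ortho to the existing fluoro group. The measured step touches the same aromatic ring, but it brings in a heptyl chain rather than a single fluoro and removes the fluoro that compound 3 keeps. It is therefore only a loose guide, and the size of an at least 4.3-fold higher number from compound 1 to compound 2 (0.63 log units; beyond the scatter) should not be carried over. Within the data shown here, with no measured example of adding a fluoro, no step beyond the usual scatter is expected in this assay, and the value of compound 1, 230 nM, remains the best anchor. The expected change is a 1.2-fold lower number from compound 1 to compound 3 (0.06 log units; within the scatter). Compound 3 is estimated at 200 nM, with an expected range of 80 nM to 600 nM.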

Compound 3, half-maximal inhibitory concentration: 220 nM
Beside the measured number, compound 3's estimate is 1.1-fold (0.04 log units) below it; the range from low to high includes it.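

In this assay, going from a 4-fluorophenyl to a 3,4-difluorophenyl gives a 1.0-fold lower number from compound 1 to compound 3 (0.02 log units; within the scatter), so the two compounds read alike and a fluoro can enter ortho to a fluoro group without a step beyond the scatter. Going by these compounds alone, the only earlier step on this aromatic ring, an at least 4.3-fold higher number from compound 1 to compound 2 (0.63 log units; beyond the scatter), put a heptyl chain in place of the fluoro, so the ring now has one change that leaves the reading alike and one that does not. The reading of compound 2 is a limit of the assay and not a number, so the true size of the heptyl step stays unknown: the limit of > 1000 nM in this assay, at which 1 of the 3 values shown sits.

The compounds shown leave open where between a single fluoro and a heptyl chain the reading begins to move, which a chlorine, a methoxy group or a shorter chain such as ethyl on this ring could help to settle. They also leave open what an amine or a carboxylic acid at this same place would do in this assay.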